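This account rests on a few compounds, and the source may have more. Where it says the series, first, only, none or still open, it means among the compounds named here.

Measured so far:
- compound 1 `Fc1ccc(-c2nc(C(Cl)(Cl)Cl)nc3ccccc23)cc1`: 500000 nM
- compound 2 `COc1cc(-c2nc(C(Cl)(Cl)Cl)nc3ccccc23)cc(OC)c1OC`: > 250000 nM (a limit of the assay, not a number)

Going by the values given here, in an ADME assay on THP-1 cells (Homo sapiens) for cytotoxicity, read by MTT assay (on this read-out lower numbers stand for higher toxicity in this test and higher numbers for lower toxicity in this test), compound 1 gives 500000 nM, the only actual number so far. Compound 2 reports > 250000 nM, and this is a limit, not a number.

Compound 3 `COc1ccc(-c2nc(C(Cl)(Cl)Cl)nc3ccccc23)cc1` has not yet been measured. It keeps the core of compound 1 and carries methoxy in place of fluoro on an aromatic carbon, para to a large group: methoxy in place of fluoro on an aromatic carbon.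

Among the compounds with values here, no measured pair shows what a single change does, so the expectation rests on very little. Compound 2, which also carries methoxy, gives > 250000 nM, again only a limit. With nothing pointing to a shift in either direction, no step beyond the scatter is expected in this assay. The expected step of a 1.3-fold lower number from compound 1 to compound 3 (0.10 log units; within the scatter) therefore stays within the scatter. For compound 3 the estimated value is 400000 nM, with an expected range of 150000 nM to 1000000 nM. A report of only a limit would also not be surprising.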

Compound 3, concentration lethal to 50% of the cells: > 250000 nM
Compound 3 ended at the assay's limit; the forecaster's own chance of this, stated with the estimate: 35%; the middle value is on the limit's open side.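

In this assay compound 3 gives > 250000 nM, which is a limit and not a number. Going by these compounds alone, no step from compound 1 to compound 3 can be read for methoxy in place of fluoro on an aromatic carbon. The compounds shown leave open how far any single change moves this read-out, because the values mostly stop at one limit: the limit of > 250000 nM in this assay, at which 2 of the 3 values shown sit.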